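The source may hold more compounds than are shown below. What is called first, only, known or untested is meant among the compounds shown, and "the series" means these compounds.

Measured compounds in an in vitro functional assay on cells for antagonist activity at metabotropic glutamate receptor 1 (Rattus norvegicus), read by inositol phosphate accumulation; a lower number here means a stronger inhibitor, a higher number a weaker inhibitor:
- compound 1, `CC1(C)CC(=O)c2cc(C#N)c(N3CCc4ccccc4C3)nc2C1`: 1500 nM
- compound 2, `CC1(C)CC(=O)c2cc(C#N)c(NC3CCCCC3)nc2C1`: 4000 nM

Compound 2 holds the highest of the two numbers in this assay. Its nearest neighbour is compound 1, whose value lies a gap below it that is beyond the usual scatter, so compound 2 is the weaker of the two measured inhibitors.

Compound 3, `CCCCNc1nc2c(cc1C#N)C(=O)CC(C)(C)C2`, has not yet been measured. Against compound 2 it differs in one place: butyl in place of cyclohexyl on a nitrogen on an aromatic ring. Among the measured compounds shown here, no measured pair shows this kind of change, so there is no step from which its size could be read. The expectation for compound 3 is a small shift toward a higher number, close to the edge of the scatter, written as a 1.5-fold higher number from compound 2 to compound 3 (0.18 log units; within the scatter). Compound 3 is thus expected to give about 6000 nM in this assay, with a range from 2000 nM to 20000 nM.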

Compound 3, half-maximal inhibitory concentration: 1700 nM
Estimate against measurement, compound 3: 3.5-fold (0.55 log units) above; measured number outside the range, below it.
By their numbers in this assay, from the lowest: compounds 1 and 3 (each within the scatter of the next); then compound 2.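

In this assay, the change from cyclohexyl to butyl on a nitrogen on an aromatic ring gives a 2.4-fold lower number from compound 2 to compound 3 (0.37 log units; beyond the scatter), the first step readable at this position, so the carbon ring of cyclohexyl is not needed to hold this level of inhibition. Among the compounds shown here, compound 1 at 1500 nM and compound 3 at 1700 nM lie within the scatter of each other, which places the open butyl chain level with the best value so far. No measurement on hand accounts for the size or direction of this step.

A single chain leaves open how inhibition follows chain length, from propyl to pentyl or hexyl. Also open, going by these compounds, is whether branched isobutyl, or a butyl chain ending in a hydroxyl or an amine, would hold the value of compound 3.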